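Removing a Ring Methyl: Expected Effect on Lipophilicity

A few compounds are considered here, and "the series" means these few. Any claim that something is new, unique, unknown or untested is made for them only; others in the source may bear on it.

Compound 1 `Cc1ccc2[nH]c(C(=O)N[C@H]3CN(S(=O)(=O)c4ccccc4)C[C@@H]3C(=O)N[C@@H]3CCCN(C)C3)cc2c1`: 2.7
Compound 2 `Cc1ccc2[nH]c(C(=O)N[C@H]3CN(S(=O)(=O)c4ccccc4)C[C@@H]3C(=O)N[C@@H]3CCCNC3)cc2c1`: 1.3
Compound 3 `Cc1ccc2[nH]c(C(=O)N[C@H]3CCN(S(=O)(=O)c4ccccc4Cl)C[C@@H]3C(=O)N[C@H]3CCCN(C)C3)cc2c1`: 3.1

These three compounds were measured in a physicochemical assay for lipophilicity, measured as octanol-water partition, at pH 7.4; on this read-out lower numbers stand for lower lipophilicity and higher numbers for higher lipophilicity. Compound 2 differs from compound 1 by hydrogen in place of methyl on an amine nitrogen in a ring, and this change gave a number 1.40 log units lower from compound 1 to compound 2 (beyond the scatter). Compound 3 carries a different core; the difference between the two cores is not broken down here. Compound 4 `Cc1ccc2[nH]c(C(=O)N[C@H]3CCN(S(=O)(=O)c4ccccc4Cl)C[C@@H]3C(=O)N[C@H]3CCCNC3)cc2c1` is not yet measured; it differs from compound 3 by hydrogen in place of methyl on an amine nitrogen in a ring, the same change as before, at the same place. Because compound 1 to compound 2 showed a number 1.40 log units lower from compound 1 to compound 2 (beyond the scatter), a step of about the same size is expected for compound 3 to compound 4, namely a number 1.40 log units lower from compound 3 to compound 4 (beyond the scatter). Starting from compound 3 at 3.1, compound 4 is therefore estimated at 1.7, expected to fall between 1.2 and 2.2 in this assay.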

Compound 4, distribution coefficient: 1.9
Beside the measured number, compound 4's estimate is 0.20 log units below it; low and high end bracket the measured number.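

In this assay the swap of methyl for hydrogen on an amine nitrogen in a ring gave a number 1.20 log units lower from compound 3 to compound 4 (beyond the scatter) and so ran in the same direction as a number 1.40 log units lower from compound 1 to compound 2 (beyond the scatter) on the core of compound 1. The change therefore carried over between these two cores as a large drop both times, but two pairs cannot show that it would hold on any further core. Nothing here explains the drop in either pair.

Replacing the methyl with an ethyl or an acetyl group on that nitrogen is not covered by the compounds shown. Going by these compounds, how either group would shift the number on these cores remains open.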